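Shifting the Fluoro Group on the Aminophenyl Amide

This account rests on a few compounds, and the source may have more. Where it says the series, first, only, none or still open, it means among the compounds named here.

Measured in a functional assay on A549 cells (Homo sapiens) for cytotoxicity, read by MTT assay, with a stated time of 72 h; on this read-out higher numbers stand for weaker inhibition and lower numbers for stronger inhibition:
compound 1 `Cc1nc2ccccn2c1-c1ccnc(NCc2ccc(C(=O)Nc3ccccc3N)cc2)n1`: 439 nM
compound 2 `Cc1nc2ncccn2c1-c1ccnc(NCc2ccc(C(=O)Nc3ccccc3N)cc2)n1`: 857 nM
compound 3 `Cc1nc2ccccn2c1-c1ccnc(NCc2ccc(C(=O)Nc3cc(F)ccc3N)cc2)n1`: 176 nM

Compound 3 has the lowest number of the three, 176 nM. Compound 4 `Cc1nc2ccccn2c1-c1ccnc(NCc2ccc(C(=O)Nc3ccc(F)cc3N)cc2)n1` has the same atoms joined differently: 2-amino-4-fluorophenyl in place of 2-amino-5-fluorophenyl on an amide-type nitrogen. Within the data shown here, no measured step moves a fluoro group, so the data do not show which way this shift should go. The closest evidence is the step that adds fluoro, a 2.5-fold lower number from compound 1 to compound 3 (0.40 log units; beyond the scatter), and compound 4 still carries a fluoro group. The other step, a 2.0-fold higher number from compound 1 to compound 2 (0.29 log units; within the scatter), alters the core and says little here. In this assay the expected change is therefore no larger than the scatter: a 1.3-fold higher number from compound 3 to compound 4 (0.10 log units; within the scatter). The estimate for compound 4 is 220 nM, with an expected range from 90 nM to 520 nM.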

Compound 4, half-maximal inhibitory concentration: 649 nM
Beside the measured number, compound 4's estimate is 3.0-fold (0.47 log units) below it; measured number outside the range, above it.
By their numbers in this assay, from the lowest: compound 3; then compounds 1, 4 and 2 (each within the scatter of the next).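

In this assay the step of a 3.7-fold higher number from compound 3 to compound 4 (0.57 log units; beyond the scatter) shows that the place of the fluoro on the aminophenyl amide counts, not just its presence. Adding fluoro does not lower the number everywhere: the step of a 1.5-fold higher number from compound 1 to compound 4 (0.17 log units; within the scatter) stands against the step of a 2.5-fold lower number from compound 1 to compound 3 (0.40 log units; beyond the scatter) on the same ring. No evidence here gives a reason for this difference. On these data alone, whether a chloro or methyl group in these two places would split the same way remains open, as does whether the split holds on the core of compound 2.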